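Cyclopropyloxy in Place of Bromo on the Shared Core

A few compounds are considered here, and "the series" means these few. Any claim that something is new, unique, unknown or untested is made for them only; others in the source may bear on it.

Measured compounds:
compound 1, `C=COc1ccccc1OC(C)C1=NCCN1`: 3160 nM
compound 2, `Cc1cccc(C)c1OC(C)C1=NCCN1`: 1480 nM
compound 3, `CC(Oc1ccccc1Br)C1=NCCN1`: 316 nM

Of the compounds shown here, three built on the shared core have been tested in a functional assay on CHO cells for agonist activity at Alpha-2B adrenergic receptor (Homo sapiens); a lower number here means that less compound is needed, a higher number that more compound is needed for the effect. Compound 1 gives 3160 nM there, compound 2 gives 1480 nM, and compound 3 gives 316 nM. Compound 3 therefore stands at the lowest number of the three: compound 2 is nearest, with a number higher by a margin beyond the scatter, and compound 1 is furthest, also beyond the scatter.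

Going by the values given here, the one step that changes a single place is a 10-fold lower number from compound 1 to compound 3 (1.00 log units; beyond the scatter), a bromo in place of vinyloxy, which lowered the number by a modest amount.

Compound 4 `CC(Oc1ccccc1OC1CC1)C1=NCCN1` has not yet been measured. cyclopropyloxy in place of bromo on an aromatic carbon This undoes the bromo and puts an oxygen-linked group back, so the measured step of a 10-fold lower number from compound 1 to compound 3 (1.00 log units; beyond the scatter) is the one that bears on it, and a rise of roughly that order is expected, though cyclopropyloxy and vinyloxy are not the same group, so the size is uncertain. Compound 4 is expected to give about 2000 nM in this assay, between 600 nM and 6500 nM. That estimate means a step of a 6.3-fold higher number from compound 3 to compound 4 (0.80 log units; beyond the scatter).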

Compound 4, half-maximal effective concentration: 12900 nM
Beside the measured number, compound 4's estimate is 6.5-fold (0.81 log units) below it; the whole stated range lies below it.
By their numbers in this assay, from the lowest: compound 3; then compound 2; then compound 1; then compound 4.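

In this assay there is a 41-fold higher number from compound 3 to compound 4 (1.61 log units; beyond the scatter) when cyclopropyloxy takes the place of bromo on the aromatic carbon, so this position responds strongly to what it carries. Oxygen-linked groups at this place also do not behave alike: there is a 4.1-fold higher number from compound 1 to compound 4 (0.61 log units; beyond the scatter) with cyclopropyl in place of vinyl on the oxygen, so a change beyond the oxygen alone moves the number by more than the scatter. No measurement offered here accounts for either step.

As far as these compounds go, whether chloro or fluoro on this carbon would keep the number near that of compound 3 remains open. From the compounds shown here alone, it is equally open where methoxy, a longer alkoxy chain or an amine at this place would fall relative to the bromo and cyclopropyloxy compounds.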